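The source may hold more compounds than are shown below. What is called first, only, known or untested is meant among the compounds shown, and "the series" means these compounds.

In an ADME assay on L02 cells (Homo sapiens) for inhibition, read by CCK-8 assay, with a stated time of 48 h (on this read-out lower numbers stand for stronger inhibition of growth and higher numbers for weaker inhibition of growth), compound 1 (`Cc1ccccc1Nc1nc(Nc2ccc(N3CCN(C)CC3)cn2)ncc1Cl`) gives 5980 nM and compound 2 (`CN1CCN(c2ccc(Nc3ncc(Cl)c(Nc4ccc(C(C)(C)C)cc4)n3)nc2)CC1`) gives 6070 nM so that compound 2 stands level with compound 1 within the scatter, and no order can be drawn between them. Next in the series is compound 3 (`COc1cccc(Nc2nc(Nc3ccc(N4CCN(C)CC4)cn3)ncc2Cl)c1`), where 3-methoxyphenyl takes the place of 4-(tert-butyl)phenyl on a nitrogen on an aromatic ring (3-methoxyphenyl in place of 4-(tert-butyl)phenyl on a nitrogen on an aromatic ring). Going by the values given here, only one measured step bears on this place (a 1.0-fold higher number from compound 1 to compound 2 (0.01 log units; within the scatter)), and it stayed within the scatter. Among the compounds with values here, no measured compound yet carries 3-methoxyphenyl, so this expectation rests on that single step. No change beyond the scatter is expected in this assay for this replacement. The expected size is a 1.0-fold lower number from compound 2 to compound 3 (0.01 log units; within the scatter) and this too lies within the scatter. For compound 3 the estimated value is 6000 nM with an expected range from 2500 nM to 12000 nM in this assay.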

Compound 3, concentration for 50% growth inhibition: 3470 nM
Beside the measured number, compound 3's estimate is 1.7-fold (0.24 log units) above it, and the stated range covers the measured number.
By their numbers in this assay, from the lowest: compounds 3, 1 and 2 (each within the scatter of the next).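

In this assay the entry of 3-methoxyphenyl on a nitrogen on an aromatic ring adds an oxygen and a hydrogen-bond acceptor at this place, yet a 1.7-fold lower number from compound 2 to compound 3 (0.24 log units; within the scatter) stays within the scatter and a 1.7-fold lower number from compound 1 to compound 3 (0.24 log units; within the scatter) does too. This place has now carried 2-methylphenyl, 4-(tert-butyl)phenyl and 3-methoxyphenyl with no separation among the three compounds, so neither the hydrogen-bond acceptor nor the difference in heavy atoms goes with a reading beyond the scatter. No available measurement offers an explanation for this flat reading.

Still open, going by these compounds, is whether a group of another kind at this nitrogen, such as an amine, a carboxylic acid or a longer alkyl chain, would move the number beyond the scatter. On these data alone, all three compounds share the same core, so how a change elsewhere would read also remains open.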